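The source may hold more compounds than are shown below. What is called first, only, known or untested is meant among the compounds shown, and "the series" means these compounds.

Measured compounds:
- compound 1, `CCCNC(=O)c1sc2nc(-c3cccs3)cc(-c3ccccc3)c2c1N`: in an assay for inhibition of 15-hydroxyprostaglandin dehydrogenase [NAD(+)] (Homo sapiens), read by fluorescence, with a stated time of 15 min, in the presence of a further agent that is not named here (a higher number here means a weaker inhibitor, a lower number a stronger inhibitor), compound 1 gives > 7500 nM, which is a limit of the assay and not a number.
- compound 2, `Nc1c(C(=O)O)sc2nc(-c3cccs3)cc(-c3ccccc3)c12`: in this assay compound 2 gives > 7500 nM, again a limit of the assay and not a number.
- compound 3, `CCC[S+]([O-])c1sc2nc(-c3cccs3)cc(-c3ccccc3)c2c1N`: in this assay compound 3 gives 2.1 nM.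

Among the measured compounds shown here, compound 3 therefore holds the only number in this set; the other two values sit at the limit (the limit of > 7500 nM in this assay, at which 2 of the 3 values shown sit). The two steps that lead to it are large: an at least 3500-fold lower number from compound 1 to compound 3 (3.55 log units; beyond the scatter) and an at least 3500-fold lower number from compound 2 to compound 3 (3.55 log units; beyond the scatter). The step from compound 1 to compound 2, a step that the two limits leave unreadable from compound 1 to compound 2, cannot be read.

Compound 4, `CCCCCC[S+]([O-])c1sc2nc(-c3cccs3)cc(-c3ccccc3)c2c1N`, differs from compound 3 only by propyl in place of hydrogen on a saturated chain carbon, three bonds along the chain from a sulfur. The sulfinyl group that marks compound 3 out is kept; the chain on it is made longer. For the measured compounds named here, none of the measured steps changes that chain, so no measured step bears directly on this one; the steps into compound 3 show only that the sulfinyl group itself is where the large number change arose. In this assay compound 4 is therefore expected to stay close to compound 3, with a step of a 1.4-fold higher number from compound 3 to compound 4 (0.15 log units; within the scatter), within the scatter. The estimate for compound 4 is 3 nM, with a range from 0.7 nM to 15 nM.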

Compound 4, half-maximal inhibitory concentration: 18 nM
For compound 4 the middle estimate is 6.0-fold (0.78 log units) below the measured one, and the stated range ends below it.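

Lengthening the chain on the sulfinyl group is not neutral in this assay: propyl in place of hydrogen on a saturated chain carbon, three bonds along the chain from a sulfur, gives an 8.6-fold higher number from compound 3 to compound 4 (0.93 log units; beyond the scatter), so this part of the molecule responds to change even though the earlier compounds left it untested. The sulfinyl group with the longer chain still stands far from the amide and the carboxylic acid, with an at least 410-fold lower number from compound 2 to compound 4 (2.61 log units; beyond the scatter) and an at least 410-fold lower number from compound 1 to compound 4 (2.61 log units; beyond the scatter), so the large gain seen with the propyl chain survives the change to hexyl. Compound 1 and compound 2 each stand at a limit of the assay and not at a number, so these two steps give only a minimum size: the limit of > 7500 nM in this assay, at which 2 of the 4 values shown sit.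

With only propyl and hexyl on the sulfinyl group, the compounds shown do not tell whether the number rises steadily with chain length, or where a methyl, butyl or pentyl chain would fall. They also leave open whether a sulfonyl group or a thioether in place of the sulfinyl group would hold the low number.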